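The compounds below may be only part of what the source reports. "The series", "measured", "known", "first", "only" and "open" are said of these compounds alone.

Values in a functional assay on HepG2 cells (Homo sapiens) for cytotoxicity, read by MTT assay, with a stated time of 72 h; a lower number here means a stronger inhibitor, a higher number a weaker inhibitor:

compound 1 `CNC(=O)c1cc(Oc2ccc(C3=NNC(c4ccc(C#N)cc4)C3)cc2)ccn1`: 15000 nM
compound 2 `CNC(=O)c1cc(Oc2ccc(C3=NNC(c4ccc(F)cc4)C3)cc2)ccn1`: 5280 nM
compound 3 `CNC(=O)c1cc(Oc2ccc(C3=NNC(c4ccc(Br)cc4)C3)cc2)ccn1`: 57600 nM

Compound 3 has the highest number of the three, 57600 nM, and so is the weakest inhibitor here. The next change goes to compound 4 `CNC(=O)c1cc(Oc2ccc(C3=NNC(c4cccc(Cl)c4Cl)C3)cc2)ccn1`, with 2,3-dichlorophenyl in place of 4-bromophenyl on a saturated ring carbon.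

The measured steps that bear on this are those that alter the same aromatic group. One is modest, a 3.8-fold higher number from compound 1 to compound 3 (0.58 log units; beyond the scatter), and one is large, an 11-fold higher number from compound 2 to compound 3 (1.04 log units; beyond the scatter). Going by the values given here, no measured compound carries chlorine or two substituents on this group, so the precedent is indirect. Compound 3 lies above compound 1 at 15000 nM and compound 2 at 5280 nM, so a modest move towards a lower number is expected in this assay, though a return to the level of compound 3 is not excluded. The expected change is a 3.2-fold lower number from compound 3 to compound 4 (0.51 log units; beyond the scatter). For compound 4 the estimated value is 18000 nM, with an expected range of 5000 nM to 60000 nM.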

Compound 4, half-maximal inhibitory concentration: 4990 nM
Compound 4: middle estimate off by 3.6-fold (0.56 log units), on the high side; measured number outside the range, below it.
By their numbers in this assay, from the lowest: compounds 4 and 2 (each within the scatter of the next); then compound 1; then compound 3.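

In this assay, a phenyl group with two chlorines on this saturated ring carbon gives a 12-fold lower number from compound 3 to compound 4 (1.06 log units; beyond the scatter), and also a 3.0-fold lower number from compound 1 to compound 4 (0.48 log units; beyond the scatter). The comparison with the remaining 4-substituted group gives a 1.1-fold lower number from compound 2 to compound 4 (0.02 log units; within the scatter), so 2,3-dichlorophenyl and 4-fluorophenyl cannot be told apart here, and a group with two substituents sits at the same level as the best of the groups with one. Compound 3, with 4-bromophenyl, now stands apart as the weakest of the four, and no measurement on hand accounts for the differences among these groups.

Still open, on these data alone, is whether the two chlorines act through their number, their placement or the element itself, as 2,3-dichlorophenyl is the only such pattern here. As far as these compounds go, how a 4-chlorophenyl, a methoxy group or an amine on this aromatic ring would fare also remains unknown.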